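Moving a Hydroxyl on a Pyridine-Linked Phenyl Ring

The source may hold more compounds than are shown below. What is called first, only, known or untested is meant among the compounds shown, and "the series" means these compounds.

Compound 1: `Oc1ccc(-c2cc(-c3cccs3)cc(-c3ccc(O)cc3)n2)cc1` — > 50000 nM
Compound 2: `Oc1ccc(-c2cc(-c3ccsc3)cc(-c3ccc(O)cc3)n2)cc1` — 4370 nM
Compound 3: `Oc1ccc(-c2cc(-c3ccco3)cc(-c3ccccc3O)n2)cc1` — > 50000 nM

In a functional assay on HeLa cells (Homo sapiens) for cytotoxicity, read by CCK-8 assay (on this read-out lower numbers stand for stronger inhibition and higher numbers for weaker inhibition), compound 3 reaches only the limit of the assay, > 50000 nM, so no number is known for it. Compound 1 also stops at a limit, > 50000 nM; compound 2 gives 4370 nM. Among the measured compounds shown here, the one measured step, an at least 11-fold lower number from compound 1 to compound 2 (1.05 log units; beyond the scatter), concerns a thiophene attached the other way round and says nothing about the phenyl rings. Compound 4, `Oc1ccc(-c2cc(-c3ccco3)cc(-c3ccc(O)cc3)n2)cc1`, differs from compound 3 in one place: 4-hydroxyphenyl in place of 2-hydroxyphenyl on an aromatic carbon. For the measured compounds named here, no measured pair shows this change, so nothing can be read from the steps about its size or direction. What remains is the observation that two of the three values sit at the limit of > 50000 nM in this assay, at which 2 of the 3 values shown sit, among them compound 3 itself. Compound 4 is therefore expected to stay near that limit, with an estimated step of a number no higher from compound 3 to compound 4 (the limit leaves the size open), and an estimate of 50000 nM in this assay, between 8000 nM and 200000 nM.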

Compound 4, half-maximal inhibitory concentration: > 50000 nM
Compound 4 was reported as a limit; the forecaster's own chance of this, stated with the estimate: 65%; the middle value lies on the limit itself.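

In this assay compound 4 gives only a limit of > 50000 nM and so moving the hydroxyl from 2-hydroxyphenyl to 4-hydroxyphenyl at this place next to the ring nitrogen brings no number into the readable range. The steps to compound 4 from compound 3 and from compound 1 cannot be read, as both ends of each are limits. Among the compounds shown here, the one readable new step is an at least 11-fold higher number from compound 2 to compound 4 (1.05 log units; beyond the scatter) with furan-2-yl in place of thiophen-3-yl on a core carrying two 4-hydroxyphenyl groups, and that leaves a single value off the limit: the limit of > 50000 nM in this assay, at which 3 of the 4 values shown sit.

Going by these compounds, whether moving the hydroxyl changes anything on a core carrying thiophen-3-yl, where a number could be read, stays open. So does how a methoxy group, an amine or a carboxylic acid in place of that hydroxyl would fare.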